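Inverting one stereocentre of compound 2

A few compounds are considered here, and "the series" means these few. Any claim that something is new, unique, unknown or untested is made for them only; others in the source may bear on it.

Within the data shown here, in a functional assay on SK-OV-3 cells (Homo sapiens) for inhibition, read by sulforhodamine B assay, with a stated time of 48 h (a higher number here means a weaker inhibitor of growth, a lower number a stronger inhibitor of growth), compound 2 `COc1ccc(C2([C@H]3C[C@H](n4cc(C)c(=O)[nH]c4=O)O[C@@H]3CO[Si](C)(C)C(C)(C)C)SCCCS2)cc1OC` gives 5250 nM as the only number so far. Among the measured compounds shown here, compound 1 `Cc1cn([C@H]2C[C@H](CC3=CC(=O)C(=O)C=C3)[C@@H](CO[Si](C)(C)C(C)(C)C)O2)c(=O)[nH]c1=O` has no result reported, so compound 2 cannot yet be ranked and no measured step is available. Compound 3 `COc1ccc(C2([C@H]3C[C@@H](n4cc(C)c(=O)[nH]c4=O)O[C@@H]3CO[Si](C)(C)C(C)(C)C)SCCCS2)cc1OC` is related to compound 2 by the two compounds have the same atoms and bonds and differ only in configuration as drawn: 1 of 3 stereo elements differ; a stereocentre at a saturated ring carbon is drawn R in compound 2 and S in compound 3 and has the same atoms and bonds. An estimated step of a 1.4-fold higher number from compound 2 to compound 3 (0.15 log units; within the scatter) is expected in this assay as a slight drift towards weaker growth inhibition and no change beyond the scatter. For compound 3 the estimate is 7500 nM with an expected range from 2800 nM to 20000 nM in this measurement.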

Compound 3, concentration for 50% growth inhibition: 17000 nM
Estimate against measurement, compound 3: 2.3-fold (0.36 log units) below; the range from low to high includes it.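

In this assay the configuration at this saturated ring carbon matters: going from R to S gives a 3.2-fold higher number from compound 2 to compound 3 (0.51 log units; beyond the scatter), something a single value could not show. Of this pair, the S form, compound 3, is the weaker growth inhibitor. The step can be assigned to this one stereocentre, because nothing else changes: the fact that compounds 2 and 3 differ only in the configuration as drawn

Still open, going by these compounds, is whether the same gap between R and S appears with a free hydroxyl group in place of the silyl ether. The two compounds also cannot show whether it holds in other cell lines.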